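This account rests on a few compounds, and the source may have more. Where it says the series, first, only, none or still open, it means among the compounds named here.

Compound 1 `Nc1cccc(-c2cn3nc(-c4cccs4)sc3n2)c1` reaches only a limit in a functional assay on L1210 cells (Mus musculus) for inhibition, read by cell counting, with a stated time of 2 days (a lower number here means a stronger inhibitor, a higher number a weaker inhibitor), > 250000 nM.
Compound 2 `CCc1ccc(-c2nn3cc(-c4cccc(N)c4)nc3s2)cc1` gives 6000 nM in this assay.
Compound 3 `C=C(Br)C(=O)Nc1cccc(-c2cn3nc(Cc4cccc(OC)c4)sc3n2)c1` gives 2000 nM in this assay.

Of the two compounds with a number, compound 3 holds the lower one, and compound 2 sits beyond the scatter above it. Compound 1 offers only a limit and cannot be ranked (the limit of > 250000 nM in this assay, at which 1 of the 3 values shown sits). Compound 4 `C=C(Br)C(=O)Nc1cccc(-c2cn3nc(-c4ccc(OCC)cc4)sc3n2)c1` has not yet been measured in this assay. The change is 4-ethoxyphenyl in place of 3-methoxybenzyl on an aromatic carbon. Going by the values given here, no measured pair isolates this change. The step of a 1.5-fold higher number from compound 3 to compound 4 (0.18 log units; within the scatter) is expected to be small, not beyond the scatter. Compound 4 is therefore estimated at 3000 nM, with a range from 800 nM to 12000 nM.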

Compound 4, half-maximal inhibitory concentration: 790 nM
Compound 4: the middle estimate sits 3.8-fold (0.58 log units) above what was measured; the measured number lies below the stated range.
By their numbers in this assay, from the lowest: compound 4; then compound 3; then compound 2. At a limit, above all of these: compound 1.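

In this assay this position gives its first reading in one place, a 2.5-fold lower number from compound 3 to compound 4 (0.40 log units; beyond the scatter), although the two groups exchanged have the same counts of heavy atoms, donors and acceptors. The number at this aromatic carbon therefore follows how those atoms are joined, not only how many there are. Nothing measured here bears on the cause of this step. The change alters the link to the aromatic ring, the place of the ether and its chain together, and the compounds shown do not separate these. On these data alone, how a 4-methoxyphenyl group, or an amine or carboxylic acid in place of the ethoxy group, would read remains open.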